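Shifting a Substituent on the Pendant Ring

A few compounds are considered here, and "the series" means these few. Any claim that something is new, unique, unknown or untested is made for them only; others in the source may bear on it.

Compound 1 `Cc1cccc(-c2cc(Cl)cc(Cl)c2/C=C/[C@@H]2C[C@@H](O)CC(=O)O2)c1` and compound 2 `Cc1ccccc1-c1cc(Cl)cc(Cl)c1/C=C/[C@@H]1C[C@@H](O)CC(=O)O1` share one core and differ only in where a methyl group sits on the pendant phenyl ring. In an assay for inhibition of 3-hydroxy-3-methylglutaryl-coenzyme A reductase (Rattus norvegicus) (on this read-out higher numbers stand for weaker inhibition and lower numbers for stronger inhibition), compound 1 gives 16 nM, while compound 2 gives 370 nM; the change a 23-fold higher number from compound 1 to compound 2 (1.36 log units; beyond the scatter) shows how much weaker inhibition the 2-methylphenyl variant produced. Within the data shown here, compound 2 therefore holds the highest number of the two measured, with compound 1 the only neighbour and well apart from it.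

Compound 3 `O=C1C[C@H](O)C[C@@H](/C=C/c2c(Cl)cc(Cl)cc2-c2cccc(F)c2)O1` is not yet measured. Relative to compound 2 the change is 3-fluorophenyl in place of 2-methylphenyl on an aromatic carbon, so the pendant ring again carries its substituent at the 3-position, as in compound 1, although now a fluorine rather than a methyl. Among the measured compounds shown here, the only step that bears on this is the large one from compound 1 to compound 2, which moved the number up sharply when the substituent left the 3-position. Moving it back is expected to reverse much of that, giving a step of a 15-fold lower number from compound 2 to compound 3 (1.17 log units; beyond the scatter) for compound 3 in this assay. Compound 3 is estimated at 25 nM, with a range from 7 nM to 90 nM.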

Compound 3, half-maximal inhibitory concentration: 70 nM
Beside the measured number, compound 3's estimate is 2.8-fold (0.45 log units) below it, and the stated range covers the measured number.
By their numbers in this assay, from the lowest: compound 1; then compound 3; then compound 2.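

In this assay, the 3-fluorophenyl group of compound 3 wins back part of what the 2-methylphenyl group of compound 2 gave up, with a 5.3-fold lower number from compound 2 to compound 3 (0.72 log units; beyond the scatter). That step changes both the substituent and its place on the ring, so on its own it cannot show how much each contributes. The comparison that keeps the place fixed, fluoro in place of methyl on the same ring carbon, gives a 4.4-fold higher number from compound 1 to compound 3 (0.64 log units; beyond the scatter), a modest step beyond the scatter, so the 3-methylphenyl and 3-fluorophenyl groups are not interchangeable here, although this difference is smaller than the large one seen when the methyl changed place.

The compounds shown leave open whether a 2-fluorophenyl group would lose as much ground as the 2-methylphenyl group, and how a 3-methoxyphenyl or 3-trifluoromethylphenyl group would compare with the two substituents seen so far. No independent information is available to explain either of these steps, so they stand as observations only.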